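A few compounds are considered here, and "the series" means these few. Any claim that something is new, unique, unknown or untested is made for them only; others in the source may bear on it.

Of the compounds shown here, three have been tested in a functional assay on A549 cells (Homo sapiens) for cytotoxicity, read by MTT assay, with a stated time of 72 h; a lower number here means a stronger inhibitor, a higher number a weaker inhibitor. Compound 1 `COc1cc(/C=C/C(=O)c2ccccc2F)cc(OC)c1OC` gives > 100000 nM, which is a limit of the assay rather than a number. Compound 2 `COc1cc(OC)c(/C=C/C(=O)c2ccccc2F)c(OC)c1` likewise gives > 100000 nM, also a limit. Going by the values given here, compound 3 `COc1cc(/C=C/C(=O)c2ccccc2F)cc(OC)c1` gives 43.6 nM, the only true number among the three. Among the compounds with values here, the one measured step, an at least 2200-fold lower number from compound 1 to compound 3 (3.36 log units; beyond the scatter), alters the ring that carries the methoxy groups, not the ring that carries the fluoro group. Compound 4 `COc1cc(/C=C/C(=O)c2ccc(OC)cc2F)cc(OC)c1` differs from compound 3 by methoxy in place of hydrogen on an aromatic carbon. Within the data shown here, no measured step touches this ring, so the step in this assay is expected to stay within the scatter, with a 1.4-fold higher number from compound 3 to compound 4 (0.14 log units; within the scatter) as the estimate. Compound 4 is therefore expected to give about 60 nM, somewhere between 10 nM and 400 nM.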

Compound 4, half-maximal inhibitory concentration: 101 nM
Beside the measured number, compound 4's estimate is 1.7-fold (0.23 log units) below it; low and high end bracket the measured number.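

In this assay the ring that carries the fluoro group now has a measured change: methoxy, para to a large group, gives a 2.3-fold higher number from compound 3 to compound 4 (0.36 log units; beyond the scatter) and so weakens compound 4 only modestly. That step is small beside an at least 2200-fold lower number from compound 1 to compound 3 (3.36 log units; beyond the scatter) on the ring that carries the methoxy groups. Nothing in the data at hand accounts for the size of the new step. On these data alone, whether an amine or a carboxylic acid at this position would give a higher or lower number stays open, and so does the effect of a longer chain such as ethoxy.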